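Series notes: ethyl for methoxy, step from compound 2 to compound 3

The source may hold more compounds than are shown below. What is called first, only, known or untested is meant among the compounds shown, and "the series" means these compounds.

Measured so far:
compound 1: `COc1cc2ncnc(Nc3cccc(Cl)c3)c2cc1OCCCCC(=O)Nc1ccc(S(N)(=O)=O)cc1`, 30400 nM
compound 2: `COc1ccc(Nc2ncnc3cc(OC)c(OCCCCC(=O)Nc4ccc(S(N)(=O)=O)cc4)cc23)cc1`, 14700 nM

For the measured compounds named here, in a functional assay on A-431 cells (Homo sapiens) for antiproliferative activity, read by MTT assay, with a stated time of 72 h (on this read-out lower numbers stand for stronger inhibition and higher numbers for weaker inhibition), compound 1 gives 30400 nM, and compound 2 gives 14700 nM; the single step so far is a 2.1-fold lower number from compound 1 to compound 2 (0.32 log units; beyond the scatter). Compound 2 therefore carries the lowest number of the two shown.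

Compound 3 `CCc1ccc(Nc2ncnc3cc(OC)c(OCCCCC(=O)Nc4ccc(S(N)(=O)=O)cc4)cc23)cc1` differs from compound 2 by ethyl in place of methoxy on an aromatic carbon. Going by the values given here, no measured step touches this change; the only step in hand concerns the aryl group on the same nitrogen and was modest in size. In this assay a step from compound 2 to compound 3 of about the same scale or none beyond the scatter is expected. Compound 3 is expected near 15000 nM, within 6000 nM to 40000 nM, which means an expected step of a 1.0-fold higher number from compound 2 to compound 3 (0.01 log units; within the scatter).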

Compound 3, half-maximal inhibitory concentration: 7220 nM
Compound 3: middle estimate off by 2.1-fold (0.32 log units), on the high side; measured number inside the range.
By their numbers in this assay, from the lowest: compound 3; then compound 2; then compound 1.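

In this assay the swap to ethyl on the aromatic carbon para to a large group gives a 2.0-fold lower number from compound 2 to compound 3 (0.31 log units; beyond the scatter) with the hydrogen-bond acceptor of methoxy gone and the heavy-atom count unchanged, so this position responds to a change of that small size. Measured against 3-chlorophenyl, 4-ethylphenyl gives a 4.2-fold lower number from compound 1 to compound 3 (0.62 log units; beyond the scatter) and so sets the lowest number of the series. Nothing in hand accounts for either step.

As far as these compounds go, whether propyl, a longer chain, or an amine at this same carbon would lower the number further stays open. Also open, from the compounds shown here alone, is whether 4-ethylphenyl holds its place with a different chain on the shared core.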